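Working notes: fluoro on compound 2

The source may report more compounds than this note shows. Statements on the series, on what has been measured and on what is new or still open speak of the compounds shown alone.

Compound 2 `O=C(NS(=O)(=O)c1ccccc1)c1ccccn1` gives 9900 nM in a functional assay on HepG2 cells (Homo sapiens) for antiproliferative activity, read by colorimetric assay and MTT assay, with a stated time of 48 h (a lower number here means a stronger inhibitor, a higher number a weaker inhibitor), and compound 1 `O=C(NS(=O)(=O)c1ccc(F)cc1)c1ccncc1` gives 12400 nM in this assay as well, so the two stand within the scatter of each other. Through fluoro in place of hydrogen on an aromatic carbon compound 2 becomes compound 3 `O=C(NS(=O)(=O)c1ccc(F)cc1)c1ccccn1` with fluoro in place of hydrogen on an aromatic carbon, para to a large group. Within the data shown here, no measured pair shows this change alone. The expected size of a 1.0-fold higher number from compound 2 to compound 3 (0.00 log units; within the scatter) stays within the scatter, with neither direction favoured. Compound 3 is estimated at 10000 nM in this assay with an expected range of 4500 nM to 22000 nM for that reading.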

Compound 3, half-maximal inhibitory concentration: 8500 nM
Compound 3: the middle estimate sits 1.2-fold (0.07 log units) above what was measured; measured number inside the range.
By their numbers in this assay, from the lowest: compounds 3, 2 and 1 (each within the scatter of the next).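

In this assay fluoro in place of hydrogen on an aromatic carbon, para to a large group, gives a 1.2-fold lower number from compound 2 to compound 3 (0.07 log units; within the scatter) and leaves the reading within the scatter. Pyridin-2-yl in place of pyridin-4-yl on a carbonyl carbon gives a 1.5-fold lower number from compound 1 to compound 3 (0.16 log units; within the scatter) and also stays within the scatter, so neither change separates these compounds. Nothing available offers a cause for either step.

On these data alone, whether an amine or methoxy in place of fluoro at this position would move the number beyond the scatter stays open.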